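Cyclobutyl for Cyclohexyl on the Amide

The compounds below may be only part of what the source reports. "The series", "measured", "known", "first", "only" and "open" are said of these compounds alone.

Compound 1 `Nc1sc(-c2ccc(Cl)cc2)c(-c2ccc(Cl)cc2)c1C(=O)N1CCCCC1=O`: 1820 nM
Compound 2 `Nc1sc(-c2ccc(Cl)cc2)c(-c2ccc(Cl)cc2)c1C(=O)NC1CCCCC1`: 2410 nM

Both values come from a functional assay on A549 cells (Homo sapiens) for inhibition, read by sulforhodamine B assay, with a stated time of 72 h; on this read-out higher numbers stand for weaker inhibition and lower numbers for stronger inhibition. Among the compounds with values here, with only two numbers available, compound 2 cannot be told apart from compound 1: the measured difference is a 1.3-fold higher number from compound 1 to compound 2 (0.12 log units; within the scatter).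

Compound 3 `Nc1sc(-c2ccc(Cl)cc2)c(-c2ccc(Cl)cc2)c1C(=O)NC1CCC1` keeps the shared core and alters a single group of compound 2: cyclobutyl in place of cyclohexyl on an amide-type nitrogen. Put simply, cyclobutyl sits in place of cyclohexyl on an amide-type nitrogen.

Within the data shown here, only one measured step bears on this change, and only loosely. Going to compound 2 from compound 1 replaced 2-oxopiperidin-1-yl with cyclohexylamino on a carbonyl carbon, and that gave a 1.3-fold higher number from compound 1 to compound 2 (0.12 log units; within the scatter). Among the measured compounds shown here, no measured pair shows what changing the ring size on this nitrogen does, so the evidence is thin. On that single small step, no shift beyond the scatter is expected in this assay. The expected change is a 1.2-fold higher number from compound 2 to compound 3 (0.07 log units; within the scatter). For compound 3 the estimated value is 2800 nM, with an expected range from 1200 nM to 6500 nM.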

Compound 3, half-maximal inhibitory concentration: 12500 nM
Estimate against measurement, compound 3: 4.5-fold (0.65 log units) below; the measured number lies above the stated range.
By their numbers in this assay, from the lowest: compounds 1 and 2 (each within the scatter of the next); then compound 3.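

In this assay, within the data shown here, the ring on the amide-type nitrogen proves to matter: cyclobutyl in place of cyclohexyl gives a 5.2-fold higher number from compound 2 to compound 3 (0.71 log units; beyond the scatter) and is the first step in this short series to clear the scatter, so a smaller carbon ring here goes with weaker inhibition of these cells. Measured against the 2-oxopiperidin-1-yl group of compound 1, the cyclobutylamino group gives a 6.9-fold higher number from compound 1 to compound 3 (0.84 log units; beyond the scatter), which makes compound 3 the weakest of the three, while compounds 1 and 2 remain within the scatter of each other. Nothing shown here says why this change raises the number.

As far as these compounds go, two ring sizes on this nitrogen cannot show how the number runs with ring size, so the value that cyclopentyl or cycloheptyl would give in this place stays open. Also open, from the compounds shown here alone, is whether an open chain such as n-butyl, or a ring carrying an amine such as piperidin-4-yl, would stay close to compound 2 at 2410 nM or move the number as far as cyclobutyl does.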